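The source may hold more compounds than are shown below. What is called first, only, known or untested is meant among the compounds shown, and "the series" means these compounds.

Measured so far in an ADME assay on RAW264.7 cells (Mus musculus) for cytotoxicity, read by MTT assay, with a stated time of 24 h, tested at 10 ug/mL; on this read-out higher numbers stand for a weaker effect at the one concentration tested and lower numbers for a stronger effect:

- compound 1, `COc1ccc(C(=O)/C=C/c2cc(OC)ccc2OC)c(O)c1`: 66.5%
- compound 2, `COc1ccc(CCCc2cccc(OC)c2OC)c(O)c1`: 63%

Two compounds have been run in this assay. Compound 1 gives 66.5% and compound 2 gives 63%. Compound 2 has the lowest of the two numbers, and its nearest neighbour is compound 1, a number only slightly higher, within the usual scatter; the two values show no difference that can be read as one.

Among the measured compounds shown here, no pair of measured compounds differs in a single place, so no step in this assay is computed. The next compound, compound 3, `COc1ccc(CCCc2ccc(OC)c(OC)c2OC)c(O)c1`, is to be measured. It differs from compound 2 in one place: methoxy in place of hydrogen on an aromatic carbon. The entering methoxy sits on an aromatic carbon of a six-membered aromatic ring of carbon only, ortho to a methoxy group, meta to a methoxy group and para to a large group.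

Without a computed step, the expectation rests on the values of compound 1 and compound 2 alone, which lie close together. The step expected from compound 2 to compound 3 is a number 1 percentage points lower from compound 2 to compound 3 (within the scatter), estimated as none beyond the scatter. For compound 3 the estimated value is 62%, in a range from 45% to 80%.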

Compound 3, a percentage reported as activity, at one concentration (the size of the read-out at that concentration, not a potency): 36.7%
Beside the measured number, compound 3's estimate is 25.3 percentage points above it; measured number below the stated range.
By their numbers in this assay, from the lowest: compound 3; then compounds 2 and 1 (each within the scatter of the next).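

In this assay, methoxy in place of hydrogen on an aromatic carbon, ortho to a methoxy group, meta to a methoxy group and para to a large group, gives a number 26.3 percentage points lower from compound 2 to compound 3 (beyond the scatter) and so a stronger effect at the one concentration tested. Among the compounds shown here, this is the only single-place step so far, and it shows that this carbon is a position where one added methoxy moves the read-out beyond the scatter, which the earlier compounds, with no pair differing in one place, could not show. The data shown give no measured basis for explaining this change.

As far as these compounds go, whether the step belongs to methoxy itself or would also follow another group at the same carbon remains open, and a hydroxy group, a fluorine atom or an ethoxy group there would help separate those readings. Also open, from the compounds shown here alone, is whether the same methoxy would give a step of similar size on the core of compound 1, and how far the step holds beyond the single concentration of this read-out.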